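This account rests on a few compounds, and the source may have more. Where it says the series, first, only, none or still open, it means among the compounds named here.

Measured so far:
Compound 1, `CC(=O)OC/C(=C\c1ccc(Cl)cc1)C(=O)c1ccccc1`: in a functional assay on HBL-100 cells (Homo sapiens) for inhibition, read by sulforhodamine B assay, with a stated time of 48 h (a lower number here means a stronger inhibitor of growth, a higher number a weaker inhibitor of growth), compound 1 gives 2300 nM.
Compound 2, `CC(=O)OC/C(=C\C1CCCCC1)C(=O)c1ccc(Cl)cc1`: in this assay compound 2 gives 31000 nM.

Compound 2 thus has the highest of the two numbers, and its gap to compound 1 lies beyond the scatter. Compound 3, `CC(=O)OC/C(=C\c1ccc(Cl)cc1)C(=O)c1ccc(Cl)cc1`, has not been measured. It differs from compound 2 by 4-chlorophenyl in place of cyclohexyl on a double-bonded chain carbon bound to a double-bonded chain carbon. A marked fall in this assay is expected, because compound 1, which carries the same 4-chlorophenyl on that carbon, gives 2300 nM. The step of an 8.9-fold lower number from compound 2 to compound 3 (0.95 log units; beyond the scatter) is therefore estimated to be a clear drop. Compound 3 is expected to give about 3500 nM, within 1200 nM to 10000 nM.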

Compound 3, concentration for 50% growth inhibition: 4000 nM
Beside the measured number, compound 3's estimate is 1.1-fold (0.06 log units) below it; the measured number falls inside the stated range.
By their numbers in this assay, from the lowest: compounds 1 and 3 (each within the scatter of the next); then compound 2.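

In this assay the swap of cyclohexyl for 4-chlorophenyl on a double-bonded chain carbon bound to a double-bonded chain carbon gives a 7.8-fold lower number from compound 2 to compound 3 (0.89 log units; beyond the scatter) and so shows that the group on this carbon matters, now with chloro on both aromatic rings of the molecule. Chloro in place of hydrogen on an aromatic carbon gives a 1.7-fold higher number from compound 1 to compound 3 (0.24 log units; within the scatter) and so makes no clear difference. No supporting measurement explains the effect of the swap.

As far as these compounds go, whether a longer chain or an amine-bearing ring in place of 4-chlorophenyl on that carbon would keep growth inhibition remains open.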